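The compounds below may be only part of what the source reports. "The series", "measured", "known", "first", "only" and "open" are said of these compounds alone.

For the measured compounds named here, in an ADME assay (liver) for metabolic stability, with Liver microsome (Rattus norvegicus) as the target, using microsomes (a lower number here means slower removal, a higher number faster removal of the compound), compound 2 `CN(C(=O)c1cc(-c2ccccc2)n[nH]1)c1ccc(OCc2ccc3ccccc3c2)cc1` gives 6.83 mL/min/kg, the lowest of the two numbers so far, while compound 1 `CN(C(=O)c1cc(-c2ccccn2)[nH]n1)c1ccc(OCc2ccc3ccccc3c2)cc1` gives 30 mL/min/kg. Compound 3 `CN(C(=O)c1ccncc1)c1ccc(OCc2ccc3ccccc3c2)cc1` keeps the shared core but carries pyridin-4-yl in place of 3-phenyl-1H-pyrazol-5-yl on a carbonyl carbon. Going by the values given here, one measured step bears on this change: a 4.4-fold lower number from compound 1 to compound 2 (0.64 log units; beyond the scatter). It lies beyond the scatter and exchanges 5-(pyridin-2-yl)-1H-pyrazol-3-yl for 3-phenyl-1H-pyrazol-5-yl at the same place. That single pair shows that the group on the carbonyl carbon can move the number, and the compound carrying pyridin-2-yl stands higher. Among the compounds with values here, no measured compound yet carries pyridin-4-yl, so the guide is indirect. A rise of comparable size is expected, a 2.9-fold higher number from compound 2 to compound 3 (0.47 log units; beyond the scatter). For compound 3 the estimated value is 20 mL/min/kg, with an expected range from 8 mL/min/kg to 50 mL/min/kg.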

Compound 3, clearance: 75 mL/min/kg
Compound 3: the middle estimate sits 3.8-fold (0.57 log units) below what was measured, outside the stated range (above it).
By their numbers in this assay, from the lowest: compound 2; then compound 1; then compound 3.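

In this assay, the place on the carbonyl carbon spans a wider range than the earlier pair showed: exchanging 3-phenyl-1H-pyrazol-5-yl for pyridin-4-yl gives an 11-fold higher number from compound 2 to compound 3 (1.04 log units; beyond the scatter) and is a large step. Exchanging 5-(pyridin-2-yl)-1H-pyrazol-3-yl for pyridin-4-yl also raises the number, with a 2.5-fold higher number from compound 1 to compound 3 (0.40 log units; beyond the scatter) and so a modest step, which leaves both compounds with a five-membered aromatic ring lower than the one with a single six-membered ring on the carbonyl carbon. Nothing measured here explains these differences.

The compounds shown leave open whether the rise goes with the missing five-membered aromatic ring or with the ring nitrogen of pyridin-4-yl. A plain phenyl on the same carbonyl carbon would separate these two readings.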